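The compounds below may be only part of what the source reports. "The series", "measured", "known", "first", "only" and "open" are said of these compounds alone.

Measured compounds:
- compound 1 `CC(C)c1ccc(N2C(=O)C=CC2OCC(F)(F)F)cc1`, 5800 nM in a functional assay on HeLa cells (Homo sapiens) for inhibition; on this read-out higher numbers stand for weaker inhibition and lower numbers for stronger inhibition
- compound 2 `CC(C)NC1CC(=O)N(c2ccc(F)c(Cl)c2)C1OCC(F)(F)F`, 6610 nM in this assay

Compound 1 gives the lower of the two half-maximal inhibitory concentrations recorded so far, but the gap between it and compound 2 lies within the scatter of repeated measurements, so the two compounds cannot be told apart on these numbers. Compound 3 `O=C1C=CC(OCC(F)(F)F)N1c1ccc([N+](=O)[O-])cc1` has not yet been measured. It differs from compound 1 in one place: nitro in place of isopropyl on an aromatic carbon. For the measured compounds named here, no step between measured compounds describes such an exchange, and compound 2 differs from compound 1 in more than one place, so nothing here tells how the number will move. The change from compound 1 to compound 3 is expected to stay within the scatter, with a step of a 1.0-fold higher number from compound 1 to compound 3 (0.01 log units; within the scatter). For compound 3 the estimate in this assay is 6000 nM, expected to fall between 2000 nM and 18000 nM.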

Compound 3, half-maximal inhibitory concentration: 2380 nM
Estimate against measurement, compound 3: 2.5-fold (0.40 log units) above; measured number inside the range.
By their numbers in this assay, from the lowest: compound 3; then compounds 1 and 2 (each within the scatter of the next).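

In this assay, for the compounds shown here, the exchange of isopropyl for nitro on an aromatic carbon, para to a large group, gives a 2.4-fold lower number from compound 1 to compound 3 (0.39 log units; beyond the scatter), so this position on the ring can move the number beyond the scatter, which the earlier compounds could not show. The two groups hold the same count of heavy atoms, 3, but nitro carries 2 hydrogen-bond acceptors and isopropyl none, so the step arises without any change in that count. No measured property of these compounds bears on the step, and what in the exchange accounts for it stays unexplained.

The compounds shown leave open whether a nitrile, an amine or a carboxylic acid at this position would give a number nearer compound 3 or compound 1. They also leave open whether nitro would lower the number on the core of compound 2.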